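Amine substituent step from compound 3 to compound 4

The source may report more compounds than this note shows. Statements on the series, on what has been measured and on what is new or still open speak of the compounds shown alone.

Values in a functional assay on CHO-K1 cells (Cricetulus griseus) for inhibition, read by MTT assay, with a stated time of 72 h; a lower number here means a stronger inhibitor, a higher number a weaker inhibitor:
compound 1 `CCCNC(=C\C(=O)/C=C/c1ccc(O)c(OC)c1)/C=C/c1ccc(O)c(OC)c1`: > 25000 nM, a limit and not a number
compound 2 `C=CCNC(=C\C(=O)/C=C/c1ccc(O)c(OC)c1)/C=C/c1ccc(O)c(OC)c1`: 7400 nM
compound 3 `CC(C)CNC(=C\C(=O)/C=C/c1ccc(O)cc1)/C=C/c1ccc(O)cc1`: 17900 nM
compound 4 `O=C(/C=C(/C=C/c1ccc(O)cc1)NC1CCCCC1)/C=C/c1ccc(O)cc1`: not yet measured

Compound 3 stands at 17900 nM, the higher of the two actual numbers in the set. Compound 2 gives 7400 nM, a gap from compound 3 that lies beyond the scatter.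

Compound 4 differs from compound 3 at one place: cyclohexyl in place of isobutyl on an amine nitrogen. In words, this is cyclohexyl in place of isobutyl on an amine nitrogen, the same difference reading isobutylamino to cyclohexylamino.

Among the measured compounds shown here, one measured step bears on this change: an at least 3.3-fold lower number from compound 1 to compound 2 (0.52 log units; beyond the scatter). That step also alters the group carried on the amine nitrogen, but it is vinyl in place of ethyl, and it sits on a core other than that of compound 3. Its size is open at one end because of the limit of > 25000 nM in this assay, at which 1 of the 3 values shown sits. It shows a response to this substituent in a single pair and offers no direction for cyclohexyl.

No step beyond the scatter is therefore expected in this assay, though the range is kept wide. The expected change is a 1.3-fold lower number from compound 3 to compound 4 (0.11 log units; within the scatter). For compound 4 the estimated value is 14000 nM. The expected range for compound 4 runs from 5000 nM to 25000 nM.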

Compound 4, half-maximal inhibitory concentration: 9200 nM
Compound 4: middle estimate off by 1.5-fold (0.18 log units), on the high side; low and high end bracket the measured number.
By their numbers in this assay, from the lowest: compounds 2, 4 and 3 (each within the scatter of the next, the first and the last beyond it). At a limit, above all of these: compound 1.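

On the core of compound 3, the amine nitrogen carries cyclohexyl as well as isobutyl in this assay with no difference beyond the scatter, as a 1.9-fold lower number from compound 3 to compound 4 (0.29 log units; within the scatter) shows. Among the compounds shown here, this is the first reading on that core, and it shows that going from an open branched chain to a six-membered carbon ring on this nitrogen does not shift the number beyond the scatter. For the compounds shown here, the only earlier step at this nitrogen, an at least 3.3-fold lower number from compound 1 to compound 2 (0.52 log units; beyond the scatter) on a different core, lies beyond the scatter, but compound 1 stands at a limit and not a number, so that step gives a bound and not a size for comparison with the new one: the limit of > 25000 nM in this assay, at which 1 of the 4 values shown sits.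

The compounds shown leave open whether vinyl on the saturated chain, as carried by compound 2, would give a step beyond the scatter on the core of compound 3, and whether cyclohexyl would behave the same way on the core of compound 1. They also leave open how a hydroxyethyl chain, a benzyl group or a piperidine ring carrying a second nitrogen would read on the amine nitrogen of either core.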